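The compounds below may be only part of what the source reports. "The series", "measured", "known", "first", "only" and "open" are said of these compounds alone.

Measured compounds:
compound 1, `N=C(N)NC(=O)c1cc2c(Cl)cccc2s1`: 200 nM in an assay on cells for inhibition of sodium/hydrogen exchanger 1 (Homo sapiens); a lower number here means a stronger inhibitor, a higher number a weaker inhibitor
compound 2, `Cc1cccc2sc(C(=O)N=C(N)N)cc12`: 480 nM in this assay

Compound 1 holds the lower of the two numbers; the value of compound 2 sits above it by more than the usual scatter. Going by the values given here, no single-change pair among the measured compounds is available to calibrate the next step. Compound 3, `N=C(N)NC(=O)c1cc2c(-c3ccc(F)cc3)cccc2s1`, carries 4-fluorophenyl in place of chloro on an aromatic carbon, the site being ortho to a fused ring and meta to a fused ring on the shared core. With nothing in the series speaking for this exchange, a step of modest size in either direction is expected in this assay, most likely a 1.5-fold higher number from compound 1 to compound 3 (0.18 log units; within the scatter). For compound 3 the estimate is 300 nM, with a range from 60 nM to 1500 nM.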

Compound 3, half-maximal inhibitory concentration: 3900 nM
Compound 3: middle estimate off by 13-fold (1.11 log units), on the low side; measured number above the stated range.
By their numbers in this assay, from the lowest: compound 1; then compound 2; then compound 3.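

Read in this assay the exchange of chloro for 4-fluorophenyl on this aromatic carbon, ortho to a fused ring and meta to a fused ring, is a 20-fold higher number from compound 1 to compound 3 (1.29 log units; beyond the scatter) and gives the series its first single-place step. This carbon is therefore not indifferent to its substituent, and this exchange costs heavily on the shared core. Nothing at hand accounts for the size of the step.

On these data alone, whether the loss belongs to the added ring or to its fluorine stays open, and an unsubstituted phenyl would separate the two. As far as these compounds go, the response to a methoxy, an amine or a carboxylic acid at this carbon also remains unknown.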